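Swapping the sulfonyl aryl group in a factor X series

The source may hold more compounds than are shown below. What is called first, only, known or untested is meant among the compounds shown, and "the series" means these compounds.

Compound 2 `CC(C)(C)c1ccc(S(=O)(=O)N[C@H]2CCN(Cc3cc4c[nH]ccc-4n3)C2=O)cc1` gives 14% in an assay on isolated protein for inhibition of coagulation factor X (Oryctolagus cuniculus), tested at 1 uM (on this read-out lower numbers stand for less inhibition and higher numbers for more inhibition at the one concentration tested (going by the name of the read-out)), level with compound 1 `CC(C)(C)c1ccc(S(=O)(=O)N[C@H]2CCN(CCNc3ccncc3)C2=O)cc1` at 14%; the step of no change at the digits printed from compound 1 to compound 2 (within the scatter) shows the exchange on the saturated chain carbon left the number unchanged. Compound 3 `O=C1[C@@H](NS(=O)(=O)c2cc3ccc(Cl)nc3s2)CCN1Cc1cc2[nH]cccc-2n1` differs from compound 2 in two places; in this assay compound 3 gives 23%, and the gap to compound 2 is within the scatter. Compound 4 `O=C1[C@@H](NS(=O)(=O)c2cc3ccnc(Cl)c3s2)CCN1Cc1cc2c[nH]ccc-2n1` carries a group of 10 heavy atoms (7 carbon, 1 nitrogen, 1 sulfur, 1 chlorine; one five-membered aromatic ring with 1 hetero atom, one six-membered aromatic ring with 1 hetero atom) in place of a group of 10 heavy atoms (10 carbon; one six-membered aromatic ring of carbon only), on a sulfonyl sulfur. Within the data shown here, no measured step isolates this change; the only comparison is the two values of compound 2 and compound 3, which lie within the scatter of each other. The expected step of a number 8 percentage points higher from compound 2 to compound 4 (within the scatter) is therefore small, at most a modest rise. Compound 4 is estimated to give 22%, within 8% to 38%.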

Compound 4, a percentage reported as inhibition, at one concentration (the size of the read-out at that concentration, not a potency): 25%
Compound 4: the middle estimate sits 3 percentage points below what was measured; measured number inside the range.
By their numbers in this assay, from the lowest: compounds 1, 2, 3 and 4 (each within the scatter of the next, the first and the last beyond it).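

At the sulfonyl sulfur, putting the chlorine-bearing two-ring group in place of 4-(tert-butyl)phenyl gives a number 11 percentage points higher from compound 2 to compound 4 (beyond the scatter) in this assay. Among these compounds, this is the first single change here that moves the number beyond the scatter, and it shows that this position can affect inhibition, though only modestly so far. Nothing available explains the rise.

The compounds shown leave open whether the chlorine itself matters or the two-ring group alone is enough. A methoxy group or an amine in place of the chlorine would help separate the two.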